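Extending the amide of compound 3 with morpholin-3-yl

The source may hold more compounds than are shown below. What is called first, only, known or untested is meant among the compounds shown, and "the series" means these compounds.

Of the compounds shown here, three sharing one core have been tested in an ADME assay on microsomes from liver (Mus musculus, strain CD-1) for metabolic stability, read by LC-MS, tested at 2 uM; a higher number here means that the compound lasts longer, a lower number that the compound disappears faster. Compound 1 `CN(C)S(=O)(=O)c1ccccc1Nc1cc(-c2ccc3ccn(C)c3c2)c2nccnc2c1` gives 0.233 h, and compound 2 `CN1CCC(NS(=O)(=O)c2ccccc2Nc2cc(-c3ccc4ccn(C)c4c3)c3nccnc3c2)C1`, which carries a (1-methylpyrrolidin-3-yl)amino in place of dimethylamino on a sulfonyl sulfur, gives 0.667 h. That single step, a 2.9-fold higher number from compound 1 to compound 2 (0.46 log units; beyond the scatter), is the only one beyond the scatter among the measured pairs. Compound 3 `CNC(=O)c1ccncc1Nc1cc(-c2ccc3ccn(C)c3c2)c2nccnc2c1`, in which the sulfonamide of the other two is replaced by a methylcarbamoyl on a pyridine-type ring, gives 0.45 h in this assay; its number lies within the usual scatter of both compound 2 and compound 1, so no order among the three can be stated from it.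

Compound 4 `Cn1ccc2ccc(-c3cc(Nc4cnccc4C(=O)NCC4COCCN4)cc4nccnc34)cc21` differs from compound 3 by morpholin-3-yl in place of hydrogen on a saturated chain carbon bound to an amide-type nitrogen. Among the compounds with values here, no measured pair changes this position, so the only guide is the step from compound 1 to compound 2, where a larger nitrogen-bearing ring entered elsewhere on the molecule and the number rose modestly. By loose analogy, a small rise or no change beyond the scatter is expected here, giving a 1.3-fold higher number from compound 3 to compound 4 (0.12 log units; within the scatter) for compound 4. Compound 4 is therefore estimated at 0.6 h, with a likely range from 0.3 h to 1.2 h.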

Compound 4, half-life: > 1 h
Compound 4 gave a limit, no number; the forecaster's own chance of this, stated with the estimate: 5%; middle value at least 1.6-fold (0.22 log units) away from the limit.
By their numbers in this assay, from the lowest: compounds 1, 3 and 2 (each within the scatter of the next, the first and the last beyond it). At a limit, above all of these: compound 4.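

In this assay, the amide side chain turns out to be a place where a change can move the number: morpholin-3-yl in place of hydrogen on the saturated chain carbon bound to the amide-type nitrogen gives an at least 2.2-fold higher number from compound 3 to compound 4 (0.34 log units; beyond the scatter). Going by these compounds, compound 4 stands at a limit and not at a number, so this step has a lower bound only and its full size stays unknown: the limit of > 1 h in this assay, at which 1 of the 4 values shown sits. Within the data shown here, until this result, the only step beyond the scatter lay on the sulfonyl sulfur, a 2.9-fold higher number from compound 1 to compound 2 (0.46 log units; beyond the scatter), so the amide series now has a measured step of its own, and in both steps the entering group holds a saturated ring with a nitrogen.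

The compounds shown leave open which part of the (morpholin-3-yl)methyl group carries the step, since a simple longer chain, an open-chain amine or a piperidine ring on the same amide nitrogen would each separate the ring, its nitrogen and its oxygen. They also leave open how far above its limit compound 4 really lies, and whether the same group would give a similar step on the sulfonamide compounds.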